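From a Benzyl Chain to a Hexyl Chain

The source may hold more compounds than are shown below. What is called first, only, known or untested is meant among the compounds shown, and "the series" means these compounds.

Three compounds have been measured in a functional assay on EL4 cells (Mus musculus) for inhibition, tested at 100 uM; on this read-out lower numbers stand for less inhibition and higher numbers for more inhibition at the one concentration tested (going by the name of the read-out):
compound 1 `OC[C@H]1OC(n2cnc3c(Nc4ccccc4)nccc32)[C@H](O)[C@@H]1O` gives 10%;
compound 2 `CN(C)c1nccc2c1ncn2C1O[C@H](CO)[C@@H](O)[C@H]1O` gives 10%;
compound 3 `OC[C@H]1OC(n2cnc3c(NCc4ccccc4)nccc32)[C@H](O)[C@@H]1O` gives 5%.

Compound 3 holds the lowest of the three numbers, yet the steps of a number 5 percentage points lower from compound 1 to compound 3 (within the scatter) and a number 5 percentage points lower from compound 2 to compound 3 (within the scatter) both sit within the scatter, so no order among the three can be claimed, and no change at the digits printed from compound 1 to compound 2 (within the scatter) is flat as well.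

Compound 4 `CCCCCCNc1nccc2c1ncn2C1O[C@H](CO)[C@@H](O)[C@H]1O` differs from compound 3 in one place: pentyl in place of phenyl on a saturated chain carbon bound to a nitrogen on an aromatic ring. Among the compounds with values here, no measured step swaps an aromatic ring for a chain, so the bearing is indirect; every change made so far at the nitrogen on the aromatic ring has left the read-out flat. Compound 4 is therefore expected to show a number 2 percentage points higher from compound 3 to compound 4 (within the scatter), nothing beyond the scatter. Compound 4 is estimated at 7%, in the range -8% to 25%.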

Compound 4, a percentage reported as inhibition, at one concentration (the size of the read-out at that concentration, not a potency): 14%
Beside the measured number, compound 4's estimate is 7 percentage points below it; the measured number falls inside the stated range.
By their numbers in this assay, from the lowest: compounds 3, 1, 2 and 4 (each within the scatter of the next).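

Replacing the aromatic ring with an open chain gives a number 9 percentage points higher from compound 3 to compound 4 (within the scatter) and, with the ring directly on the nitrogen, a number 4 percentage points higher from compound 1 to compound 4 (within the scatter) while hexylamino in place of dimethylamino gives a number 4 percentage points higher from compound 2 to compound 4 (within the scatter) in this assay at this position. Even a saturated hexyl chain therefore fails to separate itself from the aromatic and dimethylamino groups. No evidence on hand bears on this result. On these data alone, whether a longer chain, or a chain ending in an amine or a carboxylic acid, would move the read-out beyond the scatter remains open.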